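A few compounds are considered here, and "the series" means these few. Any claim that something is new, unique, unknown or untested is made for them only; others in the source may bear on it.

In a functional assay on MCF7 cells (Homo sapiens) for inhibition, read by MTT assay (a lower number here means a stronger inhibitor, a higher number a weaker inhibitor), compound 1 `COc1cc2ncnc(Nc3ccc(NC(=O)c4ccc(C)cc4)cc3)c2cc1OC` gives 19000 nM. Compound 2 `COc1cc2ncnc(Nc3ccc(NC(=O)c4ccccc4OC)cc3)c2cc1OC` reports only a limit, > 100000 nM. On these data alone, compound 3 `COc1cc2ncnc(Nc3ccc(NC(=O)c4ccc(C(C)(C)C)cc4)cc3)c2cc1OC` also reports only a limit, > 100000 nM, so its true number is unknown. That shared ceiling is the limit of > 100000 nM in this assay, at which 2 of the 3 values shown sit, and it leaves a step that the two limits leave unreadable from compound 2 to compound 3.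

Compound 4 `COc1cc2ncnc(Nc3ccc(NC(=O)c4ccccc4I)cc3)c2cc1OC` carries 2-iodophenyl in place of 4-(tert-butyl)phenyl on a carbonyl carbon. Among the measured compounds shown here, two measured steps bear on this change, both beyond the scatter: an at least 5.2-fold higher number from compound 1 to compound 2 (0.72 log units; beyond the scatter) and an at least 5.2-fold higher number from compound 1 to compound 3 (0.72 log units; beyond the scatter). Each replacement of the 4-methylphenyl group of compound 1 lost activity, so little recovery is expected. The expected change is small and toward a lower number: an at least 1.4-fold lower number from compound 3 to compound 4 (0.15 log units; that floor lies within the scatter). For compound 4 the estimated value is 70000 nM, within an expected range of 20000 nM to 170000 nM.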

Compound 4, half-maximal inhibitory concentration: 37000 nM
The estimate for compound 4 lay 1.9-fold (0.28 log units) above the measured number, within the range that was stated.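

With 2-iodophenyl on the carbonyl carbon, this assay gives a readable number again, and iodo in place of methoxy on the same ring shows that this ring does not by itself end the activity: an at least 2.7-fold lower number from compound 2 to compound 4 (0.43 log units; beyond the scatter), and likewise an at least 2.7-fold lower number from compound 3 to compound 4 (0.43 log units; beyond the scatter). Both steps give only a minimum size, as each starts from a value that is a limit: the limit of > 100000 nM in this assay, at which 2 of the 4 values shown sit. Against the 4-methylphenyl group, the change gives a 1.9-fold higher number from compound 1 to compound 4 (0.29 log units; within the scatter), so that pair cannot be ordered.

On these data alone, whether an amine or a carboxylic acid on this ring would give a lower number stays open.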